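A few compounds are considered here, and "the series" means these few. Any claim that something is new, unique, unknown or untested is made for them only; others in the source may bear on it.

Notes on the series. Compound 1 `CC(C)N(Cc1cccc(OCCCCCC(=O)O)c1)C(=O)c1ccc(-c2cccc(N(C)C)c2)cc1` is the reference point. In an ADME assay on Raji cells (Homo sapiens) for cytotoxicity, read by CellTiter-Glo and resazurin assay, with a stated time of 72 h (on this read-out lower numbers stand for an effect already at smaller amounts and higher numbers for an effect only at larger amounts of compound), compound 1 gives only a limit of the assay, > 26000 nM. Compound 2 `CC(C)N(Cc1cccc(OCCCCCC(=O)O)c1)C(=O)c1ccc(-c2ccoc2)cc1` carries furan-3-yl in place of 3-(dimethylamino)phenyl on an aromatic carbon. In this assay compound 2 likewise returns only a limit, > 26000 nM. The step that the two limits leave unreadable from compound 1 to compound 2 is therefore not readable in either direction, since both values sit at the limit of > 26000 nM in this assay, at which 2 of the 2 values shown sit. Compound 3 `CC(C)N(Cc1cccc(OCCCCCC(=O)O)c1)C(=O)c1ccc(-c2cccc(OCc3ccccc3)c2)cc1` differs from compound 1 by benzyloxy in place of dimethylamino on an aromatic carbon. Among the compounds with values here, no measured step bears directly on this exchange: the single measured step, a step that the two limits leave unreadable from compound 1 to compound 2, gives no size, and nothing else touches the dimethylamino group. With both measured compounds resting at the same limit, no step beyond the scatter is expected for compound 3 in this assay, and the most likely outcome is a third limit. The expected step is a step that the limit leaves unreadable from compound 1 to compound 3, that is, none that the assay can resolve. For compound 3 the estimate in this assay is 35000 nM, with a range from 15000 nM to 120000 nM, and a high chance that only a limit is reported again.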

Compound 3, half-maximal effective concentration: > 26000 nM
Compound 3: a limit, no number; the forecaster's own chance of this, stated with the estimate: 80%; the middle value lies beyond the limit too.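

Compound 1 and compound 3 both rest at a limit of the assay, so no step between them can be read in this assay: the limit of > 26000 nM in this assay, at which 3 of the 3 values shown sit.

The compounds shown leave open whether any exchange on the shared core would give a number rather than a limit in this assay, and how large any such step would be.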